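The source may report more compounds than this note shows. Statements on the series, on what has been measured and on what is new or still open speak of the compounds shown alone.

Measured compounds:
compound 1 `CCOc1cccc(-c2ccc(C(=O)N(Cc3cccc(OCCCCCC(=O)O)c3)C(C)C)cc2)c1` — > 20800 nM
compound 2 `CCOC(=O)CCCCCOc1ccc(CNC(C)C)cc1` — > 26000 nM

In an ADME assay on BJ cells (Homo sapiens) for cytotoxicity, read by CellTiter-Glo and resazurin assay, with a stated time of 72 h (on this read-out higher numbers stand for an effect only at larger amounts of compound and lower numbers for an effect already at smaller amounts), compound 2 gives > 26000 nM; this is a limit of the assay, not a number. For compound 2 the evidence is the limit of > 26000 nM in this assay, at which 1 of the 2 values shown sits. In this assay compound 1 gives > 20800 nM, likewise a limit rather than a number. For compound 1 the evidence is the limit of > 20800 nM in this assay, at which 1 of the 2 values shown sits. For the measured compounds named here, compound 2 therefore stands at a limit, as does the one other value shown, and no step between measured compounds can be drawn.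

Compound 3 `CCOC(=O)CCCCCOc1ccc(C(O)O)cc1` has not yet been measured in this assay. It differs from compound 2 in one place: dihydroxymethyl in place of (isopropylamino)methyl on an aromatic carbon. Going by the values given here, with compound 2 at a limit and no measured step to lean on, the step of a number no higher from compound 2 to compound 3 (the limit leaves the size open) is expected to be none beyond the scatter, so a limit is again the likelier outcome. Compound 3 is accordingly estimated at 26000 nM, within 12000 nM to 60000 nM, in this assay.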

Compound 3, half-maximal effective concentration: > 27100 nM
Compound 3 gave a limit, no number (the forecaster's own chance of this, stated with the estimate: 85%); middle value at least 1.0-fold (0.01 log units) from the limit.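

In this assay, for the compounds shown here, compound 2 and compound 3 both stand at limits, not numbers; no step between them can be read. The compounds shown leave open at what concentration either has an effect, and whether dihydroxymethyl in place of (isopropylamino)methyl shifts it.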